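A few compounds are considered here, and "the series" means these few. Any claim that something is new, unique, unknown or untested is made for them only; others in the source may bear on it.

Measured in an ADME assay on L6 cells (Rattus norvegicus) for cytotoxicity (a lower number here means a stronger inhibitor, a higher number a weaker inhibitor), so far:
- compound 1 `Cc1nc(-c2ccccn2)nc(N)c1Cl` gives 85300 nM
- compound 2 `CCN(CC)c1nc(-c2ccccn2)nc(C)c1Cl` gives 148000 nM
- compound 3 `Cc1nc(-c2ccccn2)nc(NCc2ccccc2)c1Cl` gives 70100 nM

Compound 3 lies within the scatter of compound 1, and its number is lower than that of compound 2. Compound 4 `Cc1nc(-c2ccccn2)nc(NCCC2CCCCC2)c1Cl` carries cyclohexylmethyl in place of phenyl on a saturated chain carbon bound to a nitrogen on an aromatic ring. Going by the values given here, two measured steps bear on this only indirectly: benzyl in place of hydrogen on the nitrogen (a 1.2-fold lower number from compound 1 to compound 3 (0.09 log units; within the scatter)) and diethylamino in place of amino (a 1.7-fold higher number from compound 1 to compound 2 (0.24 log units; within the scatter)). Among the compounds with values here, both stay within the scatter, and no measured pair swaps an aromatic ring for a non-aromatic one. So no step beyond the scatter is expected in this assay here. The estimated step is small (a 1.3-fold lower number from compound 3 to compound 4 (0.11 log units; within the scatter)). For compound 4 the expected value is 55000 nM (estimated range 20000 nM to 130000 nM).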

Compound 4, half-maximal inhibitory concentration: 49500 nM
Estimate against measurement, compound 4: 1.1-fold (0.05 log units) above, within the range that was stated.
By their numbers in this assay, from the lowest: compounds 4, 3, 1 and 2 (each within the scatter of the next, the first and the last beyond it).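

In this assay, going by these compounds alone, the earlier compounds changed only what sits on the nitrogen, and none replaced the aromatic ring of the benzyl group. Putting cyclohexylmethyl in place of phenyl (a 1.4-fold lower number from compound 3 to compound 4 (0.15 log units; within the scatter)) shows that, at this place, a non-aromatic ring with one more carbon leaves compound 4 within the scatter of compound 3. Nothing measured here explains this result.

Going by these compounds, whether a polar group at the end of this chain, such as an amine or a carboxylic acid, would move the number beyond the scatter remains open. So does the effect of a longer chain.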